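Changing the group on the sulfur of compound 3

This account rests on a few compounds, and the source may have more. Where it says the series, first, only, none or still open, it means among the compounds named here.

Of the compounds shown here, three have been measured in a functional assay on MGC-803 cells (Homo sapiens) for inhibition, read by MTT assay, with a stated time of 72 h; a higher number here means a weaker inhibitor, a lower number a stronger inhibitor. Compound 1 `FC(F)(F)c1ccc(CSc2nc(N3CCN(c4ccccc4)CC3)cc(C(F)(F)F)n2)cc1` gives 35200 nM, compound 2 `FC(F)(F)c1ccc(CSc2nc(N3CCN(c4ccccn4)CC3)cc(C(F)(F)F)n2)cc1` gives 23500 nM, and compound 3 `Cc1csc(Sc2cc(C(F)(F)F)nc(SCc3ccc(C(F)(F)F)cc3)n2)n1` gives 21300 nM. These numbers lie within the usual scatter of one another, so compound 3 cannot be set apart from the other two.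

Compound 4 `Cc1nnc(Sc2cc(C(F)(F)F)nc(SCc3ccc(C(F)(F)F)cc3)n2)s1` differs from compound 3 in one place, with 5-methyl-1,3,4-thiadiazol-2-yl in place of 4-methyl-1,3-thiazol-2-yl on a sulfur.

Among the compounds with values here, no measured compound carries the entering group. Within the data shown here, the only measured step, a 1.5-fold lower number from compound 1 to compound 2 (0.18 log units; within the scatter), lies within the scatter, but it puts pyridin-2-yl in place of phenyl on an amine nitrogen in a ring, so it bears on this change only loosely. Compound 1 and compound 2 lack the 4-methyl-1,3-thiazol-2-yl group altogether, yet compound 3, which carries it, gives 21300 nM, within the scatter of both.

No step beyond the scatter is therefore expected in this assay, in either direction. The expected change is small, a 1.0-fold higher number from compound 3 to compound 4 (0.01 log units; within the scatter). For compound 4 the estimated value is 22000 nM, with an expected range from 10000 nM to 45000 nM.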

Compound 4, half-maximal inhibitory concentration: 11400 nM
The estimate for compound 4 lay 1.9-fold (0.29 log units) above the measured number, within the range that was stated.
By their numbers in this assay, from the lowest: compounds 4, 3, 2 and 1 (each within the scatter of the next, the first and the last beyond it).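

In this assay, exchanging the group on this sulfur gives a 1.9-fold lower number from compound 3 to compound 4 (0.27 log units; within the scatter), so the change cannot be told apart from repeat measurement. Among the earlier compounds, no pair varied this group, and this step is the only reading at this position: going from a five-membered aromatic ring with 2 hetero atoms to one with 3, and from 2 hydrogen-bond acceptors to 3, at the same 6 heavy atoms, produces no step beyond the scatter. No supporting measurement accompanies the step, so nothing shown can say what lies behind the small difference between these two groups.

Both groups on the sulfur are methyl-bearing five-membered aromatic rings, so the compounds shown leave open how this assay responds to a group without such a ring, such as a short alkyl chain or a chain ending in a carboxylic acid. Within the data shown here, it also remains open what the methyl of the 5-methyl-1,3,4-thiadiazol-2-yl group contributes, since no compound here has a hydrogen or an amine in its place.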